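This account rests on a few compounds, and the source may have more. Where it says the series, first, only, none or still open, it means among the compounds named here.

Measured in a functional assay on MCF7 cells (Homo sapiens) for cytotoxicity, read by MTT assay, with a stated time of 72 h; a lower number here means a stronger inhibitor, a higher number a weaker inhibitor:
Compound 1 `CCN(C)C(=O)N1CCN(C(=S)SCc2cn(Cc3ccc(C)cc3)nn2)CC1` gives 40100 nM.
Compound 2 `COc1ccc(Cn2cc(CSC(=S)N3CCN(C(=O)NC(C)C)CC3)nn2)cc1` gives 19600 nM.

Of the two numbers, compound 2 stands at the lower one; its nearest neighbour is compound 1, whose value is higher by an amount beyond the usual scatter of this assay. The two compounds differ in more than one place, so the pair by itself does not tell which part of the structure carries that gap.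

Compound 3 `CCN(C)C(=O)N1CCN(C(=S)SCc2cn(Cc3ccc(OC)cc3)nn2)CC1` is not yet measured. It differs from compound 2 in one place: ethyl(methyl)amino in place of isopropylamino on a carbonyl carbon. Within the data shown here, no measured pair isolates this change, so its size is unknown. Compound 3 carries the amide of compound 1 and the benzyl substituent of compound 2. The step expected here is a 1.3-fold higher number from compound 2 to compound 3 (0.12 log units; within the scatter). Compound 3 is estimated at 26000 nM, with a range from 10000 nM to 60000 nM.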

Compound 3, half-maximal inhibitory concentration: 21400 nM
Estimate against measurement, compound 3: 1.2-fold (0.08 log units) above; measured number inside the range.
By their numbers in this assay, from the lowest: compounds 2, 3 and 1 (each within the scatter of the next, the first and the last beyond it).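

In this assay the change from isopropylamino to ethyl(methyl)amino on a carbonyl carbon gives a 1.1-fold higher number from compound 2 to compound 3 (0.04 log units; within the scatter), so removing the one hydrogen-bond donor counted for this group leaves the read-out within the scatter at this position. Compound 3 also isolates the second change, methoxy in place of methyl on an aromatic carbon, which gives a 1.9-fold lower number from compound 1 to compound 3 (0.27 log units; within the scatter) and likewise stays within the scatter. No measured evidence bears on why either step is this small.

The compounds shown leave open whether an amine, a carboxylic acid or a longer chain such as n-hexyl on that carbonyl carbon would give a step beyond the scatter. They also leave open whether chloro or hydroxy on the aromatic carbon would do so.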